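The source may report more compounds than this note shows. Statements on the series, on what has been measured and on what is new or still open speak of the compounds shown alone.

Of the compounds shown here, three sharing one core have been measured in a functional assay on HepG2 cells (Homo sapiens) for antiproliferative activity, read by MTT assay; a lower number here means a stronger inhibitor, a higher number a weaker inhibitor. Compound 1 `COc1ccc(/C=C2/SC(N3CCC[C@H]3C(=O)Nc3ccc4ncnc(Nc5cccc(Cl)c5)c4c3)=NC2=O)cc1` gives 19000 nM. Compound 2 `O=C1N=C(N2CCC[C@H]2C(=O)Nc2ccc3ncnc(Nc4cccc(Cl)c4)c3c2)S/C1=C/c1ccccc1Br` gives 24300 nM. Compound 3 `O=C1N=C(N2CCC[C@H]2C(=O)Nc2ccc3ncnc(Nc4cccc(Cl)c4)c3c2)S/C1=C/c1cccc(Br)n1` gives 2700 nM, the lowest number of the three, and its steps to the other two are beyond the scatter. Compound 4 `O=C1N=C(N2CCC[C@H]2C(=O)Nc2ccc3ncnc(Nc4cccc(Cl)c4)c3c2)S/C1=C/c1cccc(Br)c1` has not yet been measured; it differs from compound 3 in one place: 3-bromophenyl in place of 6-bromopyridin-2-yl on a double-bonded chain carbon bound to a double-bonded ring carbon. The measured steps that bear on this change are a 7.0-fold lower number from compound 1 to compound 3 (0.85 log units; beyond the scatter) and a 9.0-fold lower number from compound 2 to compound 3 (0.95 log units; beyond the scatter), in both of which a carbon-only ring was replaced by the 6-bromopyridin-2-yl group and the number fell. Returning to a carbon-only ring, now 3-bromophenyl, is therefore expected to move the number back upward, a 3.7-fold higher number from compound 3 to compound 4 (0.57 log units; beyond the scatter), though perhaps not fully. Compound 4 is expected to give 10000 nM in this assay, within a range from 3000 nM to 30000 nM.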

Compound 4, half-maximal inhibitory concentration: 21300 nM
Compound 4: the middle estimate sits 2.1-fold (0.33 log units) below what was measured; the measured number falls inside the stated range.
By their numbers in this assay, from the lowest: compound 3; then compounds 1, 4 and 2 (each within the scatter of the next).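

Replacing the 6-bromopyridin-2-yl group with the carbon-only 3-bromophenyl group gives (a 7.9-fold higher number from compound 3 to compound 4 (0.90 log units; beyond the scatter)), so a bromine-bearing ring alone does not carry the low number of compound 3. Among the carbon-only rings, neither (a 1.1-fold lower number from compound 2 to compound 4 (0.06 log units; within the scatter)) nor (a 1.1-fold higher number from compound 1 to compound 4 (0.05 log units; within the scatter)) lies beyond the scatter, so these rings cannot be told apart at this position. No evidence here explains the difference. As far as these compounds go, it remains open whether an unsubstituted pyridin-2-yl ring would keep the low number, and whether a chlorine or a methoxy group could replace the bromine on the pyridine.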